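This account rests on a few compounds, and the source may have more. Where it says the series, first, only, none or still open, it means among the compounds named here.

Measured so far:
- compound 1 `Cc1ccc(S(=O)(=O)Oc2ccccc2/C=C(\C#N)C(=O)Nc2nnc(C)s2)cc1`: 35%
- compound 2 `N#C/C(=C\c1cccc(OS(=O)(=O)c2cccs2)c1)C(=O)Nc1nnc(-c2cccs2)s1`: 50%
- compound 3 `COc1ccc(Cc2nnc(NC(=O)/C(C#N)=C/c3ccccc3OS(=O)(=O)c3ccc(C)cc3)s2)cc1`: 21%

All three values come from an ADME assay on HEK-293T cells (Homo sapiens) for inhibition, read by CCK-8 assay, with a stated time of 48 h, tested at 20 uM; on this read-out higher numbers stand for more inhibition of growth at the one concentration tested and lower numbers for less inhibition of growth. Compound 3 is the lowest of the three. Compound 4 `COc1ccc(Cc2nnc(NC(=O)/C(C#N)=C/c3ccccc3OS(=O)(=O)c3ccc([N+](=O)[O-])cc3)s2)cc1` has nitro in place of methyl on an aromatic carbon, para to a large group, so 4-methylphenyl becomes 4-nitrophenyl: nitro in place of methyl on an aromatic carbon. Among the compounds with values here, no measured step covers this change. Within the data shown here, the only step available is a number 14 percentage points lower from compound 1 to compound 3 (beyond the scatter), which is modest and lies at a different place in the structure, so it gives only a rough sense of scale. Compound 2 differs from compound 3 in more than one place and cannot isolate the change. The estimated step is a number 4 percentage points higher from compound 3 to compound 4 (within the scatter), with no clear shift expected in this assay. For compound 4 the expected value is 25%, with an estimated range of 10% to 42%.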

Compound 4, percent growth inhibition at one concentration: 17%
Compound 4: middle estimate off by 8 percentage points, on the high side; low and high end bracket the measured number.
By their numbers in this assay, from the lowest: compounds 4 and 3 (each within the scatter of the next); then compound 1; then compound 2.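

In this assay, (4-methylphenyl)sulfonyl to (4-nitrophenyl)sulfonyl gives a number 4 percentage points lower from compound 3 to compound 4 (within the scatter), the first step read at this position, since the earlier step lay elsewhere in the structure. With the methyl and nitro compounds inside the scatter of each other, this swap shows no effect that can be separated at the single concentration tested. Nothing measured here offers an explanation for this result.

Open, from the compounds shown here alone, is whether an amine or a carboxylic acid in place of nitro would separate from compound 3. Also open, going by these compounds, is whether the same swap would read alike on the core of compound 1.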